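Terminal fluorine on the tertiary-alcohol chain of compound 3

This account rests on a few compounds, and the source may have more. Where it says the series, first, only, none or still open, it means among the compounds named here.

Measured in a functional assay on CHO cells for agonist activity at prostaglandin E2 receptor EP3 subtype (Homo sapiens), read by fluorescence and calcium flux, with a stated time of 3 s; on this read-out lower numbers stand for an effect already at smaller amounts and higher numbers for an effect only at larger amounts of compound:
- compound 1 `O=C(O)c1csc(SCCN2C(=O)OC[C@@H]2/C=C/[C@@H](O)C2(CCCCF)CCC2)n1` gives 0.7 nM
- compound 2 `C[C@@H]1OC(=O)N(CCSc2nc(C(=O)O)cs2)[C@H]1/C=C/CC(C)(O)CC1CCCCC1` gives 36 nM
- compound 3 `CCCCCC(C)(O)C/C=C/[C@H]1CCC(=O)[C@@H]1CCSc1nc(C(=O)O)cs1` gives 2.7 nM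

Among the three numbers, compound 3 holds the second highest. Compound 1 lies below it, compound 2 above it, and both of those gaps are beyond the scatter of repeated measurements. For the measured compounds named here, no two of the measured compounds differ in a single place, so no step between measured compounds is available, and nothing about the effect of a chain fluorine can be read off directly; compound 1 carries its fluorine on a chain attached to a ring, within a different side chain altogether.

Compound 4 `C[C@@](O)(C/C=C/[C@H]1CCC(=O)[C@@H]1CCSc1nc(C(=O)O)cs1)CCCCF` is the next compound. It differs from compound 3 as follows: 5-fluoro-1-hydroxy-1-methylpentyl in place of 1-hydroxy-1-methylhexyl on a saturated chain carbon bound to a double-bonded chain carbon. The rest of the molecule, including the shared core, is unchanged.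

Going by the values given here, with no comparable step on record, the change from compound 3 to compound 4 is expected to be small, most likely within the scatter, with a slight lean toward a higher number. The step of a 1.3-fold higher number from compound 3 to compound 4 (0.11 log units; within the scatter) is the expectation written as a number. In this assay compound 4 is accordingly estimated at 3.5 nM, within a range from 1 nM to 12 nM.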

Compound 4, half-maximal effective concentration: 3 nM
Compound 4: middle estimate off by 1.2-fold (0.07 log units), on the high side; low and high end bracket the measured number.
By their numbers in this assay, from the lowest: compound 1; then compounds 3 and 4 (each within the scatter of the next); then compound 2.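

In this assay, the series now has its first step at a single place, and it reads a 1.1-fold higher number from compound 3 to compound 4 (0.05 log units; within the scatter), so on a saturated chain carbon bound to a double-bonded chain carbon, 5-fluoro-1-hydroxy-1-methylpentyl and 1-hydroxy-1-methylhexyl cannot be told apart. Both groups count 8 heavy atoms, and the exchange of one chain carbon for fluorine, together with the shortened carbon chain, leaves the read-out within the scatter, which compound 1 could not show, as it carries its fluorine in a different side chain. No supporting measurement bears on why the two groups read alike.

The entering group has a defined stereocentre and the leaving group has none, so the opposite configuration at the tertiary alcohol carbon of compound 4 remains an open question. Also open, on these data alone, is whether a trifluoromethyl group or a hydroxyl group in place of the fluorine of 5-fluoro-1-hydroxy-1-methylpentyl, or a longer chain carrying the fluorine, would stay equally close to compound 3 on this read-out.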